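Replacing the phenyl group of compound 2

The source may report more compounds than this note shows. Statements on the series, on what has been measured and on what is new or still open speak of the compounds shown alone.

In a functional assay on MGC-803 cells (Homo sapiens) for cytotoxicity, read by MTT assay, with a stated time of 48 h (a lower number here means a stronger inhibitor, a higher number a weaker inhibitor), compound 1 (`CC1=NN(C(=O)COc2ccc(Cl)cc2)C(c2cc(Br)ccc2O)C1`) gives 23600 nM as its half-maximal inhibitory concentration. Within the data shown here, compound 2 (`O=C(c1ccccc1)N1N=C(c2cc3ccccc3oc2=O)CC1c1ccccc1`) gives 12700 nM on the same read-out, which places it within the scatter of compound 1, the only other measured compound. Compound 3 (`CNCC(=O)N1N=C(c2cc3ccccc3oc2=O)CC1c1ccccc1`) differs from compound 2 by one change on a carbonyl carbon, with (methylamino)methyl in place of phenyl ((methylamino)methyl in place of phenyl on a carbonyl carbon). Among the measured compounds shown here, no measured pair shows what a change at this place does, and compound 1 and compound 2 differ in more than one place. The expectation in this assay is no step beyond the scatter in either direction. The expected step is a 1.2-fold higher number from compound 2 to compound 3 (0.07 log units; within the scatter) and it stays inside that scatter. For compound 3 the estimated value is 15000 nM with 5000 nM to 45000 nM as its expected range.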

Compound 3, half-maximal inhibitory concentration: 12800 nM
Compound 3: the middle estimate sits 1.2-fold (0.07 log units) above what was measured, and the stated range covers the measured number.
By their numbers in this assay, from the lowest: compounds 2, 3 and 1 (each within the scatter of the next).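

Among these compounds, at this position on the carbonyl carbon, the change shows a 1.0-fold higher number from compound 2 to compound 3 (0.00 log units; within the scatter) in this assay, the first reading of any change here. The six-membered aromatic ring of phenyl can therefore be replaced by the ringless (methylamino)methyl, with 3 heavy atoms in place of 6 and with a nitrogen, a hydrogen-bond donor and a hydrogen-bond acceptor entering, without a step beyond the scatter. No measurement shown accounts for this result.

From the compounds shown here alone, it remains open whether a carboxylic acid, a dimethylamino group or a longer chain ending in an amine on this carbonyl carbon would depart from the scatter. This single pair also leaves open whether the same swap would give a similar result on the core of compound 1.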